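Trimming One Carbon from the Ether Chain of Compound 1

The source may report more compounds than this note shows. Statements on the series, on what has been measured and on what is new or still open speak of the compounds shown alone.

Measured in a functional assay on HepG2 cells (Homo sapiens) for cytotoxicity, read by MTT assay, with a stated time of 48 h; on this read-out lower numbers stand for stronger inhibition and higher numbers for weaker inhibition:
Compound 1, `CC(C)COc1ccc2c(Cl)ccnc2c1`: 2250 nM
Compound 2, `Clc1ccnc2cc(OCc3ccccc3)ccc12`: 2680 nM
Compound 3, `Fc1ccc(COc2ccc3c(Cl)ccnc3c2)cc1`: 3010 nM

Compound 1 gives the lowest of the three numbers, yet its gaps to compound 2 and compound 3 both fall within the scatter, so the three behave alike. Compound 4, `CC(C)Oc1ccc2c(Cl)ccnc2c1`, differs from compound 1 by isopropyl in place of isobutyl on an oxygen on an aromatic ring. The two measured steps, a 1.2-fold higher number from compound 1 to compound 2 (0.08 log units; within the scatter) and a 1.1-fold higher number from compound 2 to compound 3 (0.05 log units; within the scatter), were both within the scatter; the first of them also swaps the group on that same oxygen and changed nothing of note. No step beyond the scatter is therefore expected here, and compound 4 is estimated at 2500 nM, between 1200 nM and 5200 nM, a step of a 1.1-fold higher number from compound 1 to compound 4 (0.05 log units; within the scatter) expected.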

Compound 4, half-maximal inhibitory concentration: 2050 nM
Beside the measured number, compound 4's estimate is 1.2-fold (0.09 log units) above it; the range from low to high includes it.
By their numbers in this assay, from the lowest: compounds 4, 1, 2 and 3 (each within the scatter of the next).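

In this assay, replacing isobutyl with isopropyl on this oxygen gives a 1.1-fold lower number from compound 1 to compound 4 (0.04 log units; within the scatter), which lies within the scatter. Compound 2 had shown only that a phenyl-bearing group could sit here with no step beyond the scatter; compound 4 adds that removing one carbon from the chain has no such step either. Nothing available explains this lack of response.

Going by these compounds, it remains open whether a much longer chain, an amine or a carboxylic acid on this oxygen would produce a step beyond the scatter. Changes elsewhere on the shared core also remain open.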